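The source may hold more compounds than are shown below. What is called first, only, known or untested is meant among the compounds shown, and "the series" means these compounds.

Working notes on the series. In a functional assay, read by spectrophotometry, with a stated time of 5 min (a higher number here means a weaker inhibitor, a lower number a stronger inhibitor), compound 1 (`CCOc1cc(C=C(C(=O)/C=C/c2ccc(O)c(OC)c2)C(=O)/C=C/c2ccc(O)c(OC)c2)ccc1O`) gives 123000000 nM, compound 2 (`COc1cc(/C=C/C(=O)C(=Cc2ccccc2)C(=O)/C=C/c2ccc(O)c(OC)c2)ccc1O`) gives 84400000 nM and compound 3 (`CCOc1cc(/C=C/C(=O)C(=Cc2ccc(O)c(OC)c2)C(=O)/C=C/c2ccc(O)c(OCC)c2)ccc1O`) gives 60500000 nM. The number for compound 3 lies within the scatter of that for compound 2, and it is lower than that for compound 1 by a margin beyond the scatter.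

The next comparison is compound 4 (`CCOc1cc(/C=C/C(=O)C(=Cc2ccc(OCC)c(OCC)c2)C(=O)/C=C/c2ccc(O)c(OCC)c2)ccc1O`), which differs from compound 3 by one replacement: 3,4-diethoxyphenyl in place of 4-hydroxy-3-methoxyphenyl on a double-bonded chain carbon bound to a double-bonded chain carbon. Among the measured compounds shown here, the 3,4-diethoxyphenyl group, on a double-bonded chain carbon bound to a double-bonded chain carbon, appears in no measured compound, so the data offer no direct precedent for it.

For the measured compounds named here, one measured step bears on this place: a 1.5-fold lower number from compound 1 to compound 2 (0.16 log units; within the scatter). That replacement of 3-ethoxy-4-hydroxyphenyl by phenyl stayed within the scatter, and all three measured numbers lie close together. A single step is thin evidence, but it gives no reason to expect a large shift in this assay, and no direction is favoured.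

The expected step is a 1.2-fold higher number from compound 3 to compound 4 (0.06 log units; within the scatter), which is no change beyond the scatter. For compound 4 the estimated value is 70000000 nM, with an expected range from 35000000 nM to 140000000 nM.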

Compound 4, half-maximal inhibitory concentration: 61600000 nM
Compound 4: middle estimate off by 1.1-fold (0.06 log units), on the high side; measured number inside the range.
By their numbers in this assay, from the lowest: compounds 3, 4, 2 and 1 (each within the scatter of the next, the first and the last beyond it).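

In this assay, the replacement at this place now has a direct reading for 3,4-diethoxyphenyl: a 1.0-fold higher number from compound 3 to compound 4 (0.01 log units; within the scatter). The group that enters has no hydrogen-bond donor and more heavy atoms than 4-hydroxy-3-methoxyphenyl, yet this exchange, like the earlier exchange to phenyl, stays within the scatter, so two different replacements on a double-bonded chain carbon bound to a double-bonded chain carbon now agree, though on different versions of the shared core. Nothing available explains why the number for compound 4 stays within the scatter of that for compound 3.

As far as these compounds go, every group seen at this place is a six-membered aromatic ring of carbon only, with or without ethoxy, methoxy or hydroxy substituents, so it remains open whether a ring carrying an amine or a carboxylic acid, or a saturated cyclohexyl group, would move the number beyond the scatter. From the compounds shown here alone, it is also open whether this tolerance holds on the core of compound 1, where the other two aryl groups differ from those of compound 3.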